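Removing a methoxy group on an aminophenyl-bearing core

The compounds below may be only part of what the source reports. "The series", "measured", "known", "first", "only" and "open" are said of these compounds alone.

Compound 1 `Nc1cccc(-c2cn3nc(Cc4ccccc4)sc3n2)c1` gives 7400 nM in a functional assay on L1210 cells (Mus musculus) for inhibition, read by cell counting, with a stated time of 2 days; on this read-out lower numbers stand for stronger inhibition and higher numbers for weaker inhibition. Compound 2 `COc1ccc(-c2nn3cc(-c4cccc(N)c4)nc3s2)cc1OC` gives 16000 nM, and compound 3 `COc1ccc(Cc2nn3cc(-c4cccc(N)c4)nc3s2)cc1` gives 227000 nM. The difference between the cores of compound 2 and compound 3 is not broken down here. Compound 1 differs from compound 3 by hydrogen in place of methoxy on an aromatic carbon, a change that made a 31-fold lower number from compound 3 to compound 1 (1.49 log units; beyond the scatter). Compound 4 `COc1ccc(-c2nn3cc(-c4cccc(N)c4)nc3s2)cc1` differs from compound 2 by hydrogen in place of methoxy on an aromatic carbon. This is the same kind of change, not the same: in the earlier step the place is para to a large group, whereas here it is ortho to a methoxy group and meta to a large group. Beside a 31-fold lower number from compound 3 to compound 1 (1.49 log units; beyond the scatter), the step from compound 2 to compound 4 is expected to be smaller, a 2.7-fold lower number from compound 2 to compound 4 (0.43 log units; beyond the scatter), resting on the single earlier step. Compound 4 is therefore estimated at 6000 nM, between 1500 nM and 25000 nM.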

Compound 4, half-maximal inhibitory concentration: >= 250000 nM
Compound 4: no number, only a limit; the forecaster's own chance of this, stated with the estimate: 5%; middle value at least 41-fold (1.61 log units) away from the limit.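

In this assay compound 4 gives >= 250000 nM, which is a limit of the assay and not a number. Hydrogen in place of methoxy on an aromatic carbon gave an at least 15-fold higher number from compound 2 to compound 4 (1.19 log units; beyond the scatter), so the change did not carry from one core to the other, and the two steps run in opposite directions: the same change on two cores in this assay, a 31-fold lower number (1.49 log units; beyond the scatter) from compound 3 to compound 1 and an at least 15-fold higher number (1.19 log units; beyond the scatter) from compound 2 to compound 4, at least 470-fold (2.68 log units) apart, beyond the scatter of two such steps. Going by these compounds alone, this does not show what sets the direction, since only two cores are compared, the place on the ring differs between the steps, and the second step's full size stays unknown: the limit of >= 250000 nM in this assay, at which 1 of the 4 values shown sits.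

The compounds shown leave open whether a hydroxyl, an amine or a longer alkoxy chain at these places would follow either step.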